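Acylguanidine series: cyano in place of anilino

This account rests on a few compounds, and the source may have more. Where it says the series, first, only, none or still open, it means among the compounds named here.

Measured so far:
- compound 1 `Cc1cc(SC(C)(C)C)c(S(C)(=O)=O)cc1C(=O)N=C(N)N` gives 22 nM in a functional assay for inhibition of sodium/hydrogen exchanger (Oryctolagus cuniculus); a lower number here means a stronger inhibitor, a higher number a weaker inhibitor
- compound 2 `Cc1cc(Nc2ccccc2)c(S(C)(=O)=O)cc1C(=O)N=C(N)N` gives 21 nM in this assay

Among the compounds with values here, compound 2 stands alongside compound 1 in this assay; the single measured step, a 1.0-fold lower number from compound 1 to compound 2 (0.02 log units; within the scatter), lies within the scatter. Compound 3 `Cc1cc(C#N)c(S(C)(=O)=O)cc1C(=O)N=C(N)N` differs from compound 2 by cyano in place of anilino on an aromatic carbon. Within the data shown here, no measured step introduces a cyano group, so the one step bears only loosely, showing that two different groups at this carbon gave the same number. Compound 3 is therefore expected close to compound 2, with wide uncertainty: a 1.7-fold higher number from compound 2 to compound 3 (0.22 log units; within the scatter), an estimate of 35 nM (range 10 nM to 120 nM).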

Compound 3, half-maximal inhibitory concentration: 70 nM
Compound 3: middle estimate off by 2.0-fold (0.30 log units), on the low side, and the stated range covers the measured number.
By their numbers in this assay, from the lowest: compounds 2 and 1 (each within the scatter of the next); then compound 3.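

Notes on this carbon: in this assay, anilino and (tert-butyl)sulfanyl could not be told apart, but cyano separates from both, with a 3.3-fold higher number from compound 2 to compound 3 (0.52 log units; beyond the scatter) and a 3.2-fold higher number from compound 1 to compound 3 (0.50 log units; beyond the scatter). The position therefore does not accept every group equally, though the change remains modest. Nothing at hand accounts for the shift. Still open, as far as these compounds go, is whether the higher number belongs to cyano itself or to any group as small, with 2 heavy atoms and no ring. A primary amine, a methoxy group or a chlorine atom at this carbon would bear on that.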